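This account rests on a few compounds, and the source may have more. Where it says the series, first, only, none or still open, it means among the compounds named here.

Measured so far in an assay on isolated protein for inhibition of histone deacetylase 4 (Homo sapiens), with a stated time of 1 h; on this read-out lower numbers stand for stronger inhibition and higher numbers for weaker inhibition:
compound 1 `Cc1ccc(NC(=O)COc2ccc3cc(/C=C4/SC(=O)NC4=O)ccc3c2)cc1` – 1700 nM
compound 2 `Cc1cc(Br)ccc1NC(=O)COc1ccc2cc(/C=C3/SC(=O)NC3=O)ccc2c1` – 550 nM
compound 3 `O=C(COc1ccc2cc(/C=C3/SC(=O)NC3=O)ccc2c1)Nc1ccc(F)cc1` – 1600 nM

Compound 2 gives the lowest number of the three in this assay, and both steps away from it lie beyond the scatter, so within this small set it is the strongest inhibitor. The step of a 3.1-fold lower number from compound 1 to compound 2 (0.49 log units; beyond the scatter) goes with 4-bromo-2-methylphenyl in place of 4-methylphenyl on the amide-type nitrogen; the step of a 2.9-fold higher number from compound 2 to compound 3 (0.46 log units; beyond the scatter) goes with 4-fluorophenyl in place of 4-bromo-2-methylphenyl at the same place. Between compound 1 and compound 3 the step is a 1.1-fold lower number from compound 1 to compound 3 (0.03 log units; within the scatter).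

Compound 4 `Cc1ccc(NC(=O)COc2ccc3cc(/C=C4/SC(=O)NC4=O)ccc3c2)cc1Cl` is not yet measured. It differs from compound 2 by 3-chloro-4-methylphenyl in place of 4-bromo-2-methylphenyl on an amide-type nitrogen. The two steps that bear on this, from compound 1 to compound 2 and from compound 2 to compound 3, are both modest and both involve the ring that carries a halogen together with a methyl; compound 4 keeps a halogen and a methyl on that ring, as compound 2 does. The expectation is therefore a number close to that of compound 2, with a modest rise toward compound 1 possible, giving an expected step of a 1.5-fold higher number from compound 2 to compound 4 (0.16 log units; within the scatter). For compound 4 the estimate in this assay is 800 nM, with a range from 350 nM to 2000 nM.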

Compound 4, half-maximal inhibitory concentration: 1100 nM
Compound 4: the middle estimate sits 1.4-fold (0.14 log units) below what was measured; measured number inside the range.
By their numbers in this assay, from the lowest: compounds 2, 4, 3 and 1 (each within the scatter of the next, the first and the last beyond it).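

In this assay the 3-chloro-4-methylphenyl group on the amide-type nitrogen cannot be separated from any of the three earlier groups: a 2.0-fold higher number from compound 2 to compound 4 (0.30 log units; within the scatter) and a 1.5-fold lower number from compound 3 to compound 4 (0.16 log units; within the scatter) and a 1.5-fold lower number from compound 1 to compound 4 (0.19 log units; within the scatter) all lie within the scatter. Going by these compounds alone, a ring carrying both a halogen and a methyl is therefore not enough on its own to reproduce the separation that compound 2 shows from compound 1 and compound 3, and chloro in place of hydrogen on an aromatic carbon gives no resolved step from compound 1 to compound 4. No evidence on hand explains how these rings differ in this read-out.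

The compounds shown leave open whether the lower number of compound 2 goes with the bromine, with the methyl of the 4-bromo-2-methylphenyl group, or with the two together. Also open, as far as these compounds go, is how the series responds to other kinds of group at this position, such as a dimethylamino group or a carboxylic acid on the ring, or a longer alkyl chain in place of the ring.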